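Methoxycyclohexyl on the amide nitrogen: a stability note

A few compounds are considered here, and "the series" means these few. Any claim that something is new, unique, unknown or untested is made for them only; others in the source may bear on it.

Measured compounds:
compound 1, `CC(C)(O)c1ccc(-c2cnc3c(n2)N(CC2CCOCC2)C(=O)CN3)cn1`, 83%
compound 2, `CO[C@H]1CC[C@H](CN2CC(=O)Nc3ncc(-c4ccc(C(C)(C)O)nc4)nc32)CC1`, 77%
compound 3, `CC(C)(O)c1ccc(-c2cnc3c(n2)N(CC2CCCCC2)CC(=O)N3)cn1`, 16%

In an ADME assay on S9 fraction (Rattus norvegicus) for metabolic stability, with a stated time of 60 min (on this read-out higher numbers stand for a more stable compound and lower numbers for a less stable compound), compound 1 gives the highest of the three numbers, but the gap to compound 2 lies within the scatter, so the two cannot be ranked; only compound 3 is clearly separated from both. Within the data shown here, the one step measured between compounds differing in a single place is a number 61 percentage points lower from compound 2 to compound 3 (beyond the scatter), a large loss when the methoxy on the saturated ring carbon is removed.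

Compound 4, `CO[C@H]1CC[C@H](N2C(=O)CNc3ncc(-c4ccc(C(C)(C)O)nc4)nc32)CC1`, differs from compound 1 as follows: 4-methoxycyclohexyl in place of (oxan-4-yl)methyl on an amide-type nitrogen in a ring. Among the measured compounds shown here, no measured step matches this change directly, since the substituent on the ring nitrogen moves and changes at once. The step from compound 2 to compound 3 bears on it only in that compound 4 keeps the methoxy on the saturated ring, the feature whose loss cost compound 3 so much. On that basis compound 4 is expected to stay closer to compound 1 and compound 2 than to compound 3, with at most a moderate drop, a number 15 percentage points lower from compound 1 to compound 4 (beyond the scatter), which may well remain within the scatter. The estimate for compound 4 in this assay is 68%, with a range from 40% to 90%.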

Compound 4, percent of the compound remaining: 81%
Compound 4: middle estimate off by 13 percentage points, on the low side; the range from low to high includes it.
By their numbers in this assay, from the lowest: compound 3; then compounds 2, 4 and 1 (each within the scatter of the next).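

In this assay the exchange on the amide-type nitrogen in a ring gives a number 2 percentage points lower from compound 1 to compound 4 (within the scatter) and so separates neither group from the other: 4-methoxycyclohexyl and (oxan-4-yl)methyl read alike at this position. The result therefore shows that this position accepts a six-membered ring of carbon only, carrying a methoxy, as well as a six-membered ring with a hetero atom, and that the larger entering group, with its 2 defined stereocentres, brings no change beyond the scatter. This is one pair only, and no measurement in hand accounts for the match.

The step of a number 61 percentage points lower from compound 2 to compound 3 (beyond the scatter) belongs to a different pair, so the compounds shown do not say whether the methoxy is needed on the ring at this position. Also open, going by these compounds, is how a plain cyclohexyl, a 4-hydroxycyclohexyl or a 4-aminocyclohexyl on the same amide-type nitrogen would read in this assay, and whether the other stereoisomer of 4-methoxycyclohexyl would read like compound 4 .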